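CDK8 series: ether to ethenyl ester on the pyridine core

The source may report more compounds than this note shows. Statements on the series, on what has been measured and on what is new or still open speak of the compounds shown alone.

Measured compounds:
compound 1 `CNC(=O)COc1ccncc1-c1ccc2ccccc2c1` gives 4%
compound 2 `O=C(COc1ccncc1-c1ccc2ccccc2c1)N1CCOCC1` gives 9%
compound 3 `O=C(/C=C/c1ccncc1-c1ccc2ncccc2c1)N1CCOCC1` gives 80%

In an assay on a protein complex for inhibition of CDK8/Cyclin C (Homo sapiens), with a stated time of 1 h, tested at 10 uM (a higher number here means more inhibition at the concentration tested (going by the name of the read-out), a lower number less inhibition), compound 1 stands lowest of the three numbers. Its nearest neighbour is compound 2, and the step of a number 5 percentage points higher from compound 1 to compound 2 (within the scatter) is within the scatter, so the two ether amides cannot be told apart. Among the measured compounds shown here, compound 3, the furthest, differs from compound 2 in two places at once, the linker and the second ring system, so no single step is assigned; its two values with compound 2 simply show a large gap.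

Compound 4 `CCOC(=O)/C=C/c1ccncc1-c1ccc2ccccc2c1` is the next entry. Relative to compound 1 the change is 2-(ethoxycarbonyl)ethenyl in place of (methylcarbamoyl)methoxy on an aromatic carbon. For the measured compounds named here, the only step measured, the change of amine on the carbonyl carbon, bears little on this and was within the scatter. As far as these compounds go, the ethenyl linker appears in compound 3 alone, where the high reading coincides with a changed second ring, so its share is unknown.

Compound 4 is expected to land between the ether amides and compound 3, with the step of a number 36 percentage points higher from compound 1 to compound 4 (beyond the scatter) estimated as upward, beyond the scatter but uncertain. The estimate for compound 4 is 40%, with a range from 8% to 80%.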

Compound 4, a percentage reported as inhibition, at one concentration (the size of the read-out at that concentration, not a potency): 102%
For compound 4 the middle estimate is 62 percentage points below the measured one, and the stated range ends below it.
By their numbers in this assay, from the lowest: compounds 1 and 2 (each within the scatter of the next); then compound 3; then compound 4.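

In this assay the data show a number 98 percentage points higher from compound 1 to compound 4 (beyond the scatter), with 2-(ethoxycarbonyl)ethenyl in place of (methylcarbamoyl)methoxy on the aromatic carbon opposite the ring nitrogen, while the second ring system of compound 1 stays as it is. Among the compounds shown here, the reading at this position therefore responds strongly to the group it carries, and a high reading does not require the changed second ring system of compound 3, a point the earlier compounds could not settle, since the only earlier single step, the change of amine on the carbonyl carbon, gave a number 5 percentage points higher from compound 1 to compound 2 (within the scatter). No measurement at hand explains the rise.

The step changes the linker and the chain end together, so the share of the ethenyl linker and the share of the ethyl ester remain unseparated; a carboxylic acid or a methyl amide on the same ethenyl linker, or a saturated ethyl linker carrying the ethyl ester, would divide them. As far as these compounds go, compound 4 gives 102% at a single concentration, which shows the size of the effect at that concentration only, so how its effect would compare with that of other high readers at other concentrations also remains open.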